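From Anilino to Benzylamino on a Shared Core

This account rests on a few compounds, and the source may have more. Where it says the series, first, only, none or still open, it means among the compounds named here.

Compound 1 `Nc1ccccc1NC(=O)c1ccc(Cn2cnc3c(Nc4ccccc4)nc(Cl)nc32)cc1`: 42.7%
Compound 2 `COC(CCn1cnc2c(NCc3ccc(C(=O)Nc4ccccc4N)cc3)nc(Cl)nc21)OC`: 43.7%

Both were tested in a functional assay on NCI-H460 cells (Homo sapiens) for antiproliferative activity, read by CCK-8 assay, with a stated time of 72 h, tested at 2 uM; on this read-out lower numbers stand for a weaker effect and higher numbers for a stronger effect at the one concentration tested. Compound 1 stands level with compound 2 there, the two numbers lying within the scatter of each other, so neither can be called the more active. Compound 3 `Nc1ccccc1NC(=O)c1ccc(Cn2cnc3c(NCc4ccccc4)nc(Cl)nc32)cc1` has not yet been measured; it differs from compound 1 by benzyl in place of phenyl on a nitrogen on an aromatic ring. Going by the values given here, no measured pair shows this change by itself. Among the compounds with values here, with only two near-identical values to lean on, the step of a number 2.3 percentage points higher from compound 1 to compound 3 (within the scatter) is expected to remain within the scatter, with no clear direction. Compound 3 is expected to give 45%, with a range from 30% to 60%.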

Compound 3, a percentage reported as inhibition, at one concentration (the size of the read-out at that concentration, not a potency): 44.7%
The estimate for compound 3 lay 0.3 percentage points above the measured number, within the range that was stated.
By their numbers in this assay, from the lowest: compounds 1, 2 and 3 (each within the scatter of the next).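

In this assay, going by these compounds alone, benzyl in place of phenyl on the nitrogen gives a number 2 percentage points higher from compound 1 to compound 3 (within the scatter), the first direct look at this change on the shared core. The two compounds cannot be told apart at this one concentration, so on this read-out the position accepts benzylamino as well as anilino. Nothing measured here offers an explanation for this result.

Still open, as far as these compounds go, is whether a longer chain, such as phenethyl, would also leave the read-out within the scatter. A morpholine or a carboxylic acid on the ring at this position also remains an open question.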